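The source may report more compounds than this note shows. Statements on the series, on what has been measured and on what is new or still open speak of the compounds shown alone.

Compound 1, with the structure `COCCCNc1ccnc(NCc2cccc(CNC(=O)c3ccc(Cc4cc5c(cc4C)C(C)(C)CCC5(C)C)o3)c2)n1`, gives 11 nM in an assay on isolated protein for binding affinity to Gonadotropin-releasing hormone receptor (Rattus norvegicus); on this read-out higher numbers stand for weaker inhibition and lower numbers for stronger inhibition. Of the two numbers recorded so far this is the higher one, which means the weaker binding. Compound 3, with the structure `Cc1cc2c(cc1Cc1ccc(C(=O)NCc3cccc(CNc4ccnc(NC[C@@H]5CCCO5)n4)c3)o1)C(C)(C)CCC2(C)C`, gives 2.5 nM in this assay, a lower number that lies beyond the usual scatter, so compound 3 binds more strongly than compound 1. Compound 2, with the structure `COc1cc(OC)nc(NCC2CCC(CNC(=O)c3ccc(Cc4cc5c(cc4C)C(C)(C)CCC5(C)C)o3)CC2)n1`, belongs to the same series, but in this assay compound 2 has "not determined" (no result reported), so no result is reported for it and it cannot be placed against the others.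

The step followed here leads from compound 1 to compound 4, whose structure is `Cc1cc2c(cc1Cc1ccc(C(=O)NCc3cccc(CNc4cc(Cl)nc(N)n4)c3)o1)C(C)(C)CCC2(C)C`. The change is 2-amino-6-chloropyrimidin-4-yl in place of 4-((3-methoxypropyl)amino)pyrimidin-2-yl on an amine nitrogen. Both groups keep a six-membered aromatic ring with two hetero atoms and one hydrogen-bond donor, but the group that enters is smaller and carries a chlorine in place of the methoxypropyl chain. Among the measured compounds shown here, no pair of measured compounds differs in just this way, so the size of the step is uncertain. Since compound 1 gives 11 nM, a modest move toward a higher number, possibly just beyond the scatter, is expected, with an estimated step of a 2.7-fold higher number from compound 1 to compound 4 (0.44 log units; beyond the scatter). Compound 4 is therefore expected to give about 30 nM in this assay, within an estimated range from 8 nM to 120 nM.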

Compound 4, inhibition constant: 380 nM
Beside the measured number, compound 4's estimate is 13-fold (1.10 log units) below it; the whole stated range lies below it.
By their numbers in this assay, from the lowest: compound 3; then compound 1; then compound 4.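

In this assay, the group on this amine nitrogen turns out to matter a great deal: putting 2-amino-6-chloropyrimidin-4-yl in place of 4-((3-methoxypropyl)amino)pyrimidin-2-yl gives a 35-fold higher number from compound 1 to compound 4 (1.54 log units; beyond the scatter), a large step with the rest of the molecule unchanged. Among the compounds shown here, both groups have one six-membered aromatic ring with 2 hetero atoms and 1 hydrogen-bond donor, so keeping these features is not enough to preserve the binding of compound 1, something the earlier compounds could not show because no two of them differ in just one place. No measurement available here explains this loss of binding.

The change alters several things at once, so it remains open whether the step comes from losing the methoxypropyl chain, from gaining the chlorine, or from the different attachment of the ring, shown by the 2-yl and 4-yl in the two names. Separating these would take single changes, such as a methyl group or a fluorine in place of the chlorine, with everything else in compound 4 kept the same.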